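Working notes on the step from compound 1 to compound 4

A few compounds are considered here, and "the series" means these few. Any claim that something is new, unique, unknown or untested is made for them only; others in the source may bear on it.

Compound 1 `C=CC(=O)NCc1ccc(C(=O)Nc2ccc(C)c(Nc3nccc(-c4cccnc4)n3)c2)cc1` sits at a limit of the assay rather than at a number: in an ADME assay on BaF3 cells (Mus musculus) for cytotoxicity, read by CellTiter-Glo and CCK-8 assay, with a stated time of 72 h (on this read-out higher numbers stand for weaker inhibition of growth and lower numbers for stronger inhibition of growth), compound 1 gives > 10000 nM, the limit marked by the limit of > 10000 nM in this assay, at which 1 of the 3 values shown sits. Compound 2 `C=CC(=O)Nc1ccc(C(=O)Nc2ccc(C)c(Nc3nccc(-c4cccnc4)n3)c2)cc1` gives 5600 nM in this assay, and compound 3 `C=CC(=O)Nc1cc(C(=O)Nc2ccc(C)c(Nc3nccc(-c4cccnc4)n3)c2)cc(C(F)(F)F)c1` gives 5460 nM; those two values lie within the scatter of each other, so no order between them is drawn. For the measured compounds named here, the only measured step, an at least 1.7-fold lower number from compound 1 to compound 2 (0.25 log units; that floor lies within the scatter), runs from that limit and its floor lies within the scatter, so it shows no more than that the measured compounds inhibit growth weakly.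

Compound 4 `Cc1ccc(NC(=O)c2ccc(CN(CCN(C)C)C(=O)C3CC3)cc2)cc1Nc1nccc(-c2cccnc2)n1` is not yet measured. Relative to compound 1 the change is (cyclopropylcarbonyl)(2-(dimethylamino)ethyl)amino in place of (vinylcarbonyl)amino on a saturated chain carbon bound to an aromatic carbon. Going by the values given here, no measured step bears on this change: the step from compound 1 to compound 2 puts (vinylcarbonyl)amino in place of ((vinylcarbonyl)amino)methyl on an aromatic carbon, whereas here the (vinylcarbonyl)amino group itself is exchanged and the rest of compound 1 is kept. With compound 1 at the limit, no direction beyond the scatter can be read.

The value for compound 4 is therefore expected near or at the limit, estimated at 12000 nM with a range from 4000 nM to 40000 nM. That estimate means an expected step that the limit leaves unreadable from compound 1 to compound 4, within the scatter and most likely reported again only as a limit.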

Compound 4, concentration for 50% growth inhibition: > 10000 nM
Compound 4 gave a limit, no number; the forecaster's own chance of this, stated with the estimate: 70%; the middle value is on the limit's open side.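

In this assay compound 4 gives > 10000 nM, which is a limit of the assay and not a number. On the saturated chain carbon bound to an aromatic carbon, (cyclopropylcarbonyl)(2-(dimethylamino)ethyl)amino therefore leaves the read-out at the same limit as (vinylcarbonyl)amino, and the step between those two compounds cannot be read. The one readable step, an at least 1.7-fold higher number from compound 2 to compound 4 (0.25 log units; that floor lies within the scatter), gives no order beyond the scatter, and the limit now holds more of the series: the limit of > 10000 nM in this assay, at which 2 of the 4 values shown sit.

As far as these compounds go, it remains open how far past the limit compound 1 and compound 4 lie, and whether the cyclopropylcarbonyl part or the 2-(dimethylamino)ethyl part of the entering group has any effect of its own on growth inhibition. From the compounds shown here alone, it is also open whether another group on this saturated chain carbon, such as a primary amine or a carboxylic acid, would bring the read-out off the limit to a number.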